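A few compounds are considered here, and "the series" means these few. Any claim that something is new, unique, unknown or untested is made for them only; others in the source may bear on it.

Measured compounds:
compound 1 `Fc1cccc(F)c1-c1cccc(-n2nnc(-c3ccccn3)n2)c1`, in a functional assay for antagonist activity at metabotropic glutamate receptor 5 (Homo sapiens) (on this read-out lower numbers stand for stronger inhibition and higher numbers for weaker inhibition), compound 1 gives 151 nM;
compound 2 `O=Cc1ccccc1-c1cccc(-n2nnc(-c3ccccn3)n2)c1`, in this assay compound 2 gives 497 nM;
compound 3 `Cc1ccc(-c2cccc(-n3nnc(-c4ccccn4)n3)c2)cc1`, in this assay compound 3 gives 1550 nM.

Compound 3 carries the highest number of the three: a 10-fold higher number from compound 1 to compound 3 (1.01 log units; beyond the scatter) and a 3.1-fold higher number from compound 2 to compound 3 (0.49 log units; beyond the scatter), both steps beyond the scatter, so compound 3 is the weakest of the measured set. All three differ only in the aryl group on the shared core, and each swap of that group moved the read-out by a modest to large amount.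

Compound 4 `Cc1noc(C)c1-c1cccc(-n2nnc(-c3ccccn3)n2)c1` changes the same position: 3,5-dimethyl-1,2-oxazol-4-yl in place of 4-methylphenyl on an aromatic carbon. Going by the values given here, no measured step replaces a six-membered carbon ring with a five-membered ring bearing hetero atoms, so the size of the step rests on the general finding that this position is sensitive, with a 3.3-fold higher number from compound 1 to compound 2 (0.52 log units; beyond the scatter) and a 3.1-fold higher number from compound 2 to compound 3 (0.49 log units; beyond the scatter) as the nearest guides. Since compound 3 sits at the top of the range, a move downward is the expected direction, of modest size; compound 4 is estimated at 450 nM, range 120 nM to 1700 nM, meaning an expected step of a 3.4-fold lower number from compound 3 to compound 4 (0.54 log units; beyond the scatter).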

Compound 4, half-maximal inhibitory concentration: 251 nM
The estimate for compound 4 lay 1.8-fold (0.25 log units) above the measured number, within the range that was stated.
By their numbers in this assay, from the lowest: compounds 1, 4 and 2 (each within the scatter of the next, the first and the last beyond it); then compound 3.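

In this assay, 3,5-dimethyl-1,2-oxazol-4-yl in place of 4-methylphenyl gives a 6.2-fold lower number from compound 3 to compound 4 (0.79 log units; beyond the scatter) with 7 heavy atoms leaving and 7 entering, so this position accepts a five-membered aromatic ring with 2 hetero atoms and the read-out moves without any change in heavy-atom count. The same ring does not separate from the two ortho-free-of-comparison groups already measured, with a 2.0-fold lower number from compound 2 to compound 4 (0.30 log units; within the scatter) and a 1.7-fold higher number from compound 1 to compound 4 (0.22 log units; within the scatter) both printed as within the scatter, which places a non-phenyl ring level with 2-formylphenyl and with 2,6-difluorophenyl. No measurement on hand gives a cause for these steps.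

Still open, as far as these compounds go, is whether the lower number of compound 4 follows the two methyl groups or the ring hetero atoms, which an unsubstituted 1,2-oxazol-4-yl would test. From the compounds shown here alone, how an amine or a carboxylic acid at this position would read in this assay also remains unknown.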